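A few compounds are considered here, and "the series" means these few. Any claim that something is new, unique, unknown or untested is made for them only; others in the source may bear on it.

Measured compounds:
compound 1 `Oc1cc(F)ccc1C(c1ccc2ccoc2c1O)N1CCCCC1` gives 1070 nM
compound 2 `CCc1ccc(C(Nc2ccccn2)c2ccc3cccnc3c2O)cc1` gives 170 nM

Both values come from an assay for inhibition of protein disulfide-isomerase (Homo sapiens), with a stated time of 1 h; on this read-out higher numbers stand for weaker inhibition and lower numbers for stronger inhibition. Compound 2 has the lower of the two numbers; compound 1, the nearest, sits well beyond the scatter above it, so compound 2 is the stronger inhibitor of the pair in this assay. Among the compounds with values here, compound 1 and compound 2 differ throughout, so no single step between measured compounds is available.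

Compound 3 `Cc1cc(C)c(C(Nc2ccccn2)c2ccc3cccnc3c2O)c(C)c1` is the next analogue of compound 2. The change is 2,4,6-trimethylphenyl in place of 4-ethylphenyl on a saturated chain carbon bound to an aromatic carbon and a nitrogen on an aromatic ring. Within the data shown here, no measured step bears on an exchange of this kind, so the expectation rests only on compound 2 itself. A small move, if any, toward weaker inhibition seems most plausible in this assay, and the expected step is a 1.8-fold higher number from compound 2 to compound 3 (0.25 log units; within the scatter). Compound 3 is expected to give about 300 nM, with a likely range from 100 nM to 1000 nM.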

Compound 3, half-maximal inhibitory concentration: 190 nM
Beside the measured number, compound 3's estimate is 1.6-fold (0.20 log units) above it; measured number inside the range.
By their numbers in this assay, from the lowest: compounds 2 and 3 (each within the scatter of the next); then compound 1.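

In this assay, within the data shown here, the exchange of 4-ethylphenyl for 2,4,6-trimethylphenyl on a saturated chain carbon bound to an aromatic carbon and a nitrogen on an aromatic ring gives the only readable step (a 1.1-fold higher number from compound 2 to compound 3 (0.05 log units; within the scatter)), and it lies within the scatter. Compound 2 and compound 3 therefore cannot be told apart in this assay, so on this single pair the position accepts either of these two methyl- or ethyl-bearing phenyl groups, with 8 or 9 heavy atoms of carbon only, without a measurable difference. Nothing at hand explains this result.

On these data alone, whether the same holds for a phenyl ring carrying an amine or a carboxylic acid remains open. So does the effect of a saturated ring, such as cyclohexyl, at this position.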